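Thiophene in Place of Chlorophenyl: an Agonist Step

The source may hold more compounds than are shown below. What is called first, only, known or untested is meant among the compounds shown, and "the series" means these compounds.

Compound 1 `COc1ccc(C(C)NC(=O)/N=C(\N)NCCCc2sc(N)nc2C)cc1` gives 0.91 in a functional assay on Right cardiac atrium for agonist activity at histamine H2 receptor (Cavia porcellus), with a stated time of 30 min, in the presence of a further agent that is not named here; a higher number here means a larger maximal response, a lower number a smaller maximal response. Compound 2 `Cc1nc(N)sc1CCCN/C(N)=N/C(=O)NC(C)c1ccc(Cl)cc1` gives 0.93. Compound 3 `Cc1nc(N)sc1CCCN/C(N)=N/C(=O)NC(C)c1ccc(OC(F)(F)F)cc1` gives 0.61.

Compound 2 holds the highest number of the three, although the step a number 0.020 higher from compound 1 to compound 2 (within the scatter) is within the scatter, and only its gap to compound 3 is wide: a number 0.32 lower from compound 2 to compound 3 (beyond the scatter). Compound 4 `Cc1nc(N)sc1CCCN/C(N)=N/C(=O)NC(C)c1cccs1` is not yet measured. It differs from compound 2 in one place: thiophen-2-yl in place of 4-chlorophenyl on a saturated chain carbon bound to an amide-type nitrogen and a saturated chain carbon.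

The measured steps all change a group on the aromatic ring while the ring itself stays. a number 0.020 higher from compound 1 to compound 2 (within the scatter) shows that one such exchange left the maximal response unchanged, while a number 0.32 lower from compound 2 to compound 3 (beyond the scatter) shows that another pulled it down. Replacing the whole ring is a different kind of change, so these steps give only a loose guide; a smaller ring can be tolerated or can cost response, and the direction is not settled by the data.

Compound 4 is expected to give about 0.85, between 0.6 and 1. The expected step is a number 0.080 lower from compound 2 to compound 4 (within the scatter), which is not beyond the scatter, with a wide margin on the low side.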

Compound 4, intrinsic activity: the largest response reached, as a fraction of the reference agonist's: 0.88
The estimate for compound 4 lay 0.030 below the measured number; measured number inside the range.
By their numbers in this assay, from the lowest: compound 3; then compounds 4, 1 and 2 (each within the scatter of the next).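

Until now only groups on the aromatic ring had changed, whereas here the whole ring changes: in this assay thiophen-2-yl in place of 4-chlorophenyl gives a number 0.050 lower from compound 2 to compound 4 (within the scatter) and thiophen-2-yl in place of 4-methoxyphenyl gives a number 0.030 lower from compound 1 to compound 4 (within the scatter). Among these compounds, then, a high maximal response at this saturated chain carbon does not require a six-membered aromatic ring of carbon only, though compound 3 shows that keeping that ring does not ensure a high response either. Nothing given here explains this result.

The compounds shown leave open whether a saturated ring such as cyclohexyl would hold the response at this place. They also leave open what a chloro or trifluoromethoxy group on the thiophene would do.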